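Pyridin-3-yl Replaces 3-Fluorophenyl in a Sulfonamide Benzamide Series

The source may hold more compounds than are shown below. What is called first, only, known or untested is meant among the compounds shown, and "the series" means these compounds.

Of the compounds shown here, two have been measured in an assay on MDA-MB-231 cells for binding affinity to C-X-C chemokine receptor type 4 (Homo sapiens), read by immunofluorescence and microscopy, with stated times of 10 min and 30 min; on this read-out lower numbers stand for an effect already at smaller amounts and higher numbers for an effect only at larger amounts of compound. Compound 1 `Cc1ccc(S(=O)(=O)NCc2ccc(CNC(=O)c3ccccc3Cl)cc2)cc1` gives 10 nM, and compound 2 `Cc1ccc(S(=O)(=O)NCc2ccc(CNC(=O)c3cccc(F)c3)cc2)cc1` gives 1 nM. Among the measured compounds shown here, the single step between them, a 10-fold lower number from compound 1 to compound 2 (1.00 log units; beyond the scatter), is the only comparison available. On these numbers compound 2 stands lowest of the two, with compound 1 as its nearest neighbour at a higher value.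

Compound 3 `Cc1ccc(S(=O)(=O)NCc2ccc(CNC(=O)c3cccnc3)cc2)cc1` has not yet been measured in this assay. It differs from compound 2 by pyridin-3-yl in place of 3-fluorophenyl on a carbonyl carbon. For the measured compounds named here, no measured step changes the aromatic ring at the carbonyl carbon in this way, so the only related evidence is the step from compound 1 to compound 2, which shows that swapping the aryl ring at this position can move the number beyond the scatter. Compound 3 is therefore expected to land close to compound 2 in this assay, with a step of a 3.0-fold higher number from compound 2 to compound 3 (0.48 log units; beyond the scatter) considered likely and a somewhat higher number slightly favoured. The estimate for compound 3 in this assay is 3 nM, within a range of 0.7 nM to 15 nM.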

Compound 3, effective concentration (reported as EC, without a stated level of effect): > 1000 nM
Compound 3: no number, only a limit (the forecaster's own chance of this, stated with the estimate: 5%); at least 330-fold (2.52 log units) between middle value and limit.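

In this assay, the group on the carbonyl carbon proves far less tolerant of change than the earlier modest step suggested, as pyridin-3-yl in place of 3-fluorophenyl brings an at least 1000-fold higher number from compound 2 to compound 3 (3.00 log units; beyond the scatter). Measured against the weaker of the two earlier compounds, the same ring still brings an at least 100-fold higher number from compound 1 to compound 3 (2.00 log units; beyond the scatter), so the change is large from either starting point. Compound 3 has no number, only a limit, which leaves the full size of both steps unknown: the limit of > 1000 nM in this assay, at which 1 of the 3 values shown sits.

On these data alone, whether the change in compound 3 comes from gaining the ring nitrogen or from losing the fluorine stays open, and a plain phenyl or a pyridin-3-yl carrying fluorine would separate the two. Also open, as far as these compounds go, is whether a pyridin-4-yl or pyridin-2-yl on the same carbonyl carbon would stay near compound 2 or fall with compound 3.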